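Amide-linked series: phenyl for methyl on the saturated ring

A few compounds are considered here, and "the series" means these few. Any claim that something is new, unique, unknown or untested is made for them only; others in the source may bear on it.

Compound 1 `CC1CCN(C(=O)CCCNC(=O)c2ccc(S(C)(=O)=O)c([N+](=O)[O-])c2)CC1` is the reference point of the pair measured so far. In an assay on isolated protein for inhibition of thyroid hormone receptor beta (Homo sapiens), read by fluorescence polarization (on this read-out higher numbers stand for weaker inhibition and lower numbers for stronger inhibition), compound 1 gives > 60000 nM, which is a limit of the assay and not a number. Going by the values given here, compound 2 `CS(=O)(=O)c1ccc(C(=O)NCCCC(=O)N2Cc3ccccc3C2)cc1[N+](=O)[O-]` is the one measured neighbour that differs from it in one place. In this assay compound 2 gives > 60000 nM, again a limit. Among the compounds with values here, the step that the two limits leave unreadable from compound 1 to compound 2 is therefore not readable in size, and the evidence the limit of > 60000 nM in this assay, at which 2 of the 2 values shown sit, shows only that both values sit at the limit. Compound 3 `CS(=O)(=O)c1ccc(C(=O)NCCCC(=O)N2CCC(c3ccccc3)CC2)cc1[N+](=O)[O-]` is not yet measured; it differs from compound 1 by phenyl in place of methyl on a saturated ring carbon. Within the data shown here, no measured step bears on this change, so no direction can be set from the data. Compound 3 is expected to stay near the limit, with an expected step that the limit leaves unreadable from compound 1 to compound 3. Compound 3 is estimated at 80000 nM, within a range of 20000 nM to 300000 nM.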

Compound 3, half-maximal inhibitory concentration: > 60000 nM
Compound 3 ended at the assay's limit; the forecaster's own chance of this, stated with the estimate: 75%; the middle value lies beyond the limit too.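

Compound 1 and compound 3 give no readable step, as both values are limits of the assay: the limit of > 60000 nM in this assay, at which 3 of the 3 values shown sit.
The compounds shown leave open whether phenyl in place of methyl on a saturated ring carbon changes inhibition at all in this assay, and by how much.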